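Methyl on the ring oxygen in a small series

The source may report more compounds than this note shows. Statements on the series, on what has been measured and on what is new or still open speak of the compounds shown alone.

Four compounds share one core and differ in the group on the aromatic ring and in where that group sits. Compound 1 is `CC1(/C=C/c2ccccc2O)C=CC(=O)O1` and compound 3 is `COc1ccccc1/C=C/C1(C)C=CC(=O)O1`; compound 2 is `CC1(/C=C/c2ccc(O)cc2)C=CC(=O)O1` and compound 4 is `COc1ccc(/C=C/C2(C)C=CC(=O)O2)cc1`. How the core of compound 1 relates to the core of compound 2 is not broken down here.

In a functional assay on HaCaT cells (Homo sapiens) for inhibition, read by sulforhodamine B assay, with a stated time of 48 h (a lower number here means a stronger inhibitor of growth, a higher number a weaker inhibitor of growth), compound 1 gives 57300 nM, compound 3 gives 30800 nM and compound 2 gives 81200 nM. The values of compound 2 and compound 1 lie within the scatter of each other. Compound 2 and compound 3 show a gap beyond the scatter, with compound 3 holding the lower number.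

The change from compound 1 to compound 3 is methyl in place of hydrogen on an oxygen on an aromatic ring, and it made a 1.9-fold lower number from compound 1 to compound 3 (0.27 log units; within the scatter). Compound 4 carries the same change relative to compound 2: methyl in place of hydrogen on an oxygen on an aromatic ring, at the same place, on an oxygen on an aromatic ring whose other neighbours are aromatic carbon. Only this one earlier instance of the change exists among these compounds, so the expectation rests on a single step. The step from compound 2 to compound 4 is expected to be a 1.9-fold lower number from compound 2 to compound 4 (0.28 log units; within the scatter), much like the earlier one, because a 1.9-fold lower number from compound 1 to compound 3 (0.27 log units; within the scatter) was modest. Compound 4 is accordingly expected to give about 43000 nM, most likely between 20000 nM and 90000 nM, in this assay.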

Compound 4, concentration for total growth inhibition: 316000 nM
Compound 4: middle estimate off by 7.3-fold (0.87 log units), on the low side; measured number outside the range, above it.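

In this assay, hydroxy to methoxy on the core of compound 2 gave a 3.9-fold higher number from compound 2 to compound 4 (0.59 log units; beyond the scatter) and so did not repeat what the same change did on the core of compound 1. The earlier step lies within the scatter, so this is better read as a change with no clear effect on one core and a weakening of growth inhibition on the other than as two clear steps in opposite directions, and one pair per core gives no general rule and no reason for the difference. What can be stated is that a result for this change on one of these cores was not a safe guide to its result on the other, since the two steps differ by more than the scatter of such steps: the same change on two cores in this assay, a 1.9-fold lower number (0.27 log units; within the scatter) from compound 1 to compound 3 and a 3.9-fold higher number (0.59 log units; beyond the scatter) from compound 2 to compound 4, 7.2-fold (0.86 log units) apart, beyond the scatter of two such steps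

The compounds shown leave open whether the gap between the cores belongs to the methyl group alone or would also appear with a longer chain on the same oxygen, such as ethyl. They also leave open how either core would respond if the hydroxy group gave way to a different group altogether, such as an amine or a carboxylic acid.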